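The source may hold more compounds than are shown below. What is called first, only, known or untested is meant among the compounds shown, and "the series" means these compounds.

Working notes on the series in a functional assay on MCF7 cells (Homo sapiens) for cytotoxicity, read by MTT assay, with a stated time of 72 h; a higher number here means a weaker inhibitor, a lower number a stronger inhibitor. Compound 1 `COc1ccc(Nc2cc(C)nc(SCc3nc4ccccc4[nH]3)n2)cc1` gives 61100 nM in this assay. Compound 2 `Cc1cc(Nc2ccc(Cl)cc2)nc(SCc2nc3ccccc3[nH]2)n1` gives 33600 nM in this assay, and the step of a 1.8-fold lower number from compound 1 to compound 2 (0.26 log units; within the scatter) is small. Compound 3 `Cc1cc(NCCO)nc(SCc2nc3ccccc3[nH]2)n1` reports only a limit, > 100000 nM, not a number. On these data alone, compound 3 thus sits at the limit of > 100000 nM in this assay, at which 1 of the 3 values shown sits, and its true value is unknown beyond that.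

Compound 4 `COc1ccccc1Nc1cc(C)nc(SCc2nc3ccccc3[nH]2)n1` is not yet measured and differs from compound 3 by 2-methoxyphenyl in place of 2-hydroxyethyl on a nitrogen on an aromatic ring. For the measured compounds named here, two measured steps bear on this change in the opposite direction: an at least 1.6-fold higher number from compound 1 to compound 3 (0.21 log units; that floor lies within the scatter) and an at least 2.9-fold higher number from compound 2 to compound 3 (0.47 log units; beyond the scatter). Replacing 4-methoxyphenyl or 4-chlorophenyl on that nitrogen by 2-hydroxyethyl moved the number to the limit, so restoring an aromatic substituent in the form of 2-methoxyphenyl is expected to give a lower number, by a modest amount. Compound 4 is estimated at 60000 nM, within 25000 nM to 150000 nM in this assay. The expected step of an at least 1.6-fold lower number from compound 3 to compound 4 (0.22 log units; that floor lies within the scatter) carries added uncertainty, as compound 3 is only a limit.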

Compound 4, half-maximal inhibitory concentration: > 100000 nM
Compound 4: no number, only a limit (the forecaster's own chance of this, stated with the estimate: 30%); middle value at least 1.6-fold (0.22 log units) from the limit.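

In this assay, an aromatic ring on this nitrogen does not by itself keep the number readable: compound 4, with 2-methoxyphenyl, reports only a limit, as compound 3 does with 2-hydroxyethyl, and the step between these two cannot be read: the limit of > 100000 nM in this assay, at which 2 of the 4 values shown sit.

Against 4-chlorophenyl the change is clear, with an at least 2.9-fold higher number from compound 2 to compound 4 (0.47 log units; beyond the scatter). Against 4-methoxyphenyl it is not, with an at least 1.6-fold higher number from compound 1 to compound 4 (0.21 log units; that floor lies within the scatter), so the series does not yet separate 2-methoxyphenyl from 4-methoxyphenyl.

On these data alone, how far compound 3 and compound 4 lie beyond their limits remains unknown. Also open, as far as these compounds go, is whether a 4-bromophenyl or 2-chlorophenyl group on this nitrogen, or a longer chain ending in an amine, would give a readable number.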